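Dimethylsulfamoyl Added to the Chain of Compound 3

A few compounds are considered here, and "the series" means these few. Any claim that something is new, unique, unknown or untested is made for them only; others in the source may bear on it.

compound 1 `Nc1nc2ccc(C(=O)C(F)(F)F)cc2s1` — > 10 mg/kg
compound 2 `Nc1nc2cccc(OC(F)(F)F)c2s1` — > 10 mg/kg
compound 3 `CCn1c(=N)sc2cc(OC(F)(F)F)ccc21` — 5 mg/kg

In a functional assay on the whole organism with Rattus norvegicus as the target (a lower number here means that less compound is needed, a higher number that more compound is needed for the effect), compound 3 is the only one of the three to give a number, 5 mg/kg. Compound 1 gives > 10 mg/kg, which is a limit of the assay. Compound 2 also gives > 10 mg/kg, again a limit. Compound 3 therefore stands alone against (the limit of > 10 mg/kg in this assay, at which 2 of the 3 values shown sit).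

Compound 4 `CN(C)S(=O)(=O)CCn1c(=N)sc2cc(OC(F)(F)F)ccc21` differs from compound 3 in one place: dimethylsulfamoyl in place of hydrogen on a saturated chain carbon, two bonds along the chain from an aromatic nitrogen. Going by the values given here, no measured pair shows this change, so nothing here gauges it. In this assay a step of no more than the usual scatter is expected in either direction. Compound 4 is expected to give 6 mg/kg, within 2.5 mg/kg to 15 mg/kg. That estimate implies a step of a 1.2-fold higher number from compound 3 to compound 4 (0.08 log units; within the scatter).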

Compound 4, dose for half-maximal effect: > 10 mg/kg
Compound 4: no number, only a limit; the forecaster's own chance of this, stated with the estimate: 30%; at least 1.6-fold (0.22 log units) between middle value and limit.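

In this assay, dimethylsulfamoyl in place of hydrogen on this saturated chain carbon gives the only step that can be read among these compounds: an at least 2.0-fold higher number from compound 3 to compound 4 (0.30 log units; that floor lies within the scatter). Compound 4 gives > 10 mg/kg, which is a limit of the assay and not a number, so the step has a floor but no known size. Going by these compounds alone, compound 3 remains the only compound with a number, and the others share one limit: the limit of > 10 mg/kg in this assay, at which 3 of the 4 values shown sit.

The compounds shown leave open whether an amine or a carboxylic acid at this carbon, or a longer chain, would give a number rather than a limit in this assay.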